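The source may hold more compounds than are shown below. What is called first, only, known or untested is meant among the compounds shown, and "the series" means these compounds.

The measured compounds:
compound 1 `CCCCc1ccc(CNCc2ccccc2)c(=O)n1Cc1ccc(-c2ccccc2-c2nn[nH]n2)cc1` gives 1 nM in a functional assay (aorta) for antagonist activity, with Oryctolagus cuniculus as the target; on this read-out higher numbers stand for weaker inhibition and lower numbers for stronger inhibition;
compound 2 `CCCCc1ccc(CNC(=O)NC2CCCCC2)c(=O)n1Cc1ccc(-c2ccccc2-c2nn[nH]n2)cc1` gives 90 nM;
compound 3 `CCCCc1ccc(CNC(=O)N(C)C)c(=O)n1Cc1ccc(-c2ccccc2-c2nn[nH]n2)cc1` gives 2 nM.

Compound 2 has the highest number of the three, and so the weakest inhibition, since both a 90-fold higher number from compound 1 to compound 2 (1.95 log units; beyond the scatter) and a 45-fold lower number from compound 2 to compound 3 (1.65 log units; beyond the scatter) lie beyond the scatter. The step under discussion leads to compound 4 `CCCCc1ccc(CN(C)S(=O)(=O)c2ccc(C)cc2)c(=O)n1Cc1ccc(-c2ccccc2-c2nn[nH]n2)cc1`, in which (methyl((4-methylphenyl)sulfonyl)amino in place of (cyclohexylcarbamoyl)amino on a saturated chain carbon bound to an aromatic carbon). For the measured compounds named here, no measured compound carries the entering group, so nothing directly tests it. What does bear on the step are the two changes at this position: a 90-fold higher number from compound 1 to compound 2 (1.95 log units; beyond the scatter) and a 45-fold lower number from compound 2 to compound 3 (1.65 log units; beyond the scatter) both show that the (cyclohexylcarbamoyl)amino group goes with the high number of compound 2, while the other groups at this place give low numbers. Replacing it is therefore expected to give a lower number in this assay, though the size is uncertain because the entering group is new. Compound 4 is estimated at 10 nM, between 1.5 nM and 60 nM, which means an expected step of a 9.0-fold lower number from compound 2 to compound 4 (0.95 log units; beyond the scatter).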

Compound 4, half-maximal inhibitory concentration: 8 nM
Beside the measured number, compound 4's estimate is 1.3-fold (0.10 log units) above it; low and high end bracket the measured number.
By their numbers in this assay, from the lowest: compounds 1 and 3 (each within the scatter of the next); then compound 4; then compound 2.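

In this assay, swapping (cyclohexylcarbamoyl)amino for methyl((4-methylphenyl)sulfonyl)amino gives an 11-fold lower number from compound 2 to compound 4 (1.05 log units; beyond the scatter). The entering group has more heavy atoms than the one it replaces and no hydrogen-bond donors, so a larger group at this place does not by itself bring a number as high as that of compound 2. It still falls short of the two best groups here, with a 4.0-fold higher number from compound 3 to compound 4 (0.60 log units; beyond the scatter) and an 8.0-fold higher number from compound 1 to compound 4 (0.90 log units; beyond the scatter), and nothing measured here explains these differences.

Going by these compounds, it remains open whether a smaller methylsulfonyl group on the same nitrogen would reach the low numbers of compound 1 and compound 3. The separate roles of the methyl on the nitrogen and the methyl on the phenyl ring are also unresolved.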